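This account rests on a few compounds, and the source may have more. Where it says the series, first, only, none or still open, it means among the compounds named here.

Of the compounds shown here, three that share one core have been tested in a functional assay on CHO cells for antagonist activity at Orexin receptor type 2 (Homo sapiens), read by FLIPR and calcium flux; on this read-out higher numbers stand for weaker inhibition and lower numbers for stronger inhibition. Compound 1 `Cc1occc1-c1nnc(SCC(=O)Nc2ccc(F)c(Cl)c2)n1Cc1ccco1` gives 39.8 nM. Compound 2 `Cc1occc1-c1nnc(SCC(=O)Nc2ccc(Cl)cc2)n1Cc1ccco1` gives 100 nM, and the step of a 2.5-fold higher number from compound 1 to compound 2 (0.40 log units; beyond the scatter) is a modest one. Compound 3 `CC(=O)c1ccc(NC(=O)CSc2nnc(-c3ccoc3C)n2Cc2ccco2)cc1` gives 31.6 nM. On these numbers compound 3 sits within the scatter of compound 1, as the step of a 1.3-fold lower number from compound 1 to compound 3 (0.10 log units; within the scatter) shows, while the step of a 3.2-fold lower number from compound 2 to compound 3 (0.50 log units; beyond the scatter) sets it apart from compound 2.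

Compound 4 `Cc1occc1-c1nnc(SCC(=O)NN2CCc3ccccc32)n1Cc1ccco1` has not yet been measured. It differs from compound 3 by 2,3-dihydro-1H-indol-1-yl in place of 4-acetylphenyl on an amide-type nitrogen. All three measured steps swap one aromatic group for another on that amide-type nitrogen, and all were of modest size; none of them replaces the aromatic group with a ring joined through nitrogen, so none bears directly on this change, and the change is larger than any of them. A step towards a higher number is expected, a 3.2-fold higher number from compound 3 to compound 4 (0.50 log units; beyond the scatter), with wide uncertainty. Compound 4 is therefore estimated at 100 nM, within a range of 25 nM to 500 nM.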

Compound 4, inhibition constant: 1000 nM
Compound 4: middle estimate off by 10-fold (1.00 log units), on the low side, and the stated range ends below it.
By their numbers in this assay, from the lowest: compounds 3 and 1 (each within the scatter of the next); then compound 2; then compound 4.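

Putting 2,3-dihydro-1H-indol-1-yl on the amide-type nitrogen weakens inhibition in this assay against all three earlier compounds, as the steps show (a 32-fold higher number from compound 3 to compound 4 (1.50 log units; beyond the scatter)), (a 25-fold higher number from compound 1 to compound 4 (1.40 log units; beyond the scatter)) and (a 10-fold higher number from compound 2 to compound 4 (1.00 log units; beyond the scatter)). The swaps among compound 1, compound 2 and compound 3 moved the number far less, so this position accepts those substituted phenyl groups much better than it accepts the new group, even though 4-acetylphenyl and 2,3-dihydro-1H-indol-1-yl have the same count of heavy atoms. No measurement here explains the size of this rise.

The change replaces both the ring system and the atom through which it is attached, and the compounds shown cannot separate these two parts. A dimethylamino group or a plain phenylamino group on that nitrogen would be needed to tell them apart.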